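Taking the chloro off compound 3

This account rests on a few compounds, and the source may have more. Where it says the series, first, only, none or still open, it means among the compounds named here.

Of the compounds shown here, three on a shared core have been tested in a functional assay on K562 cells (Homo sapiens) for antiproliferative activity, read by MTT assay, with a stated time of 72 h; a lower number here means a stronger inhibitor, a higher number a weaker inhibitor. Compound 1 `COc1cc(-n2ncnc2-c2ccc(C)cc2)cc(OC)c1OC` gives > 10000 nM, which is a limit of the assay and not a number. Compound 2 `COc1cc(-n2ncnc2-c2ccc(Cl)cc2)cc(OC)c1OC` gives > 10000 nM, which is likewise a limit. Among the compounds with values here, compound 3 `CCOc1ccc(-c2ncnn2-c2cc(OC)c(OC)c(OC)c2)cc1Cl` gives 20 nM, the only actual number in the set.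

Compound 4 `CCOc1ccc(-c2ncnn2-c2cc(OC)c(OC)c(OC)c2)cc1` departs from compound 3 by a single change: hydrogen in place of chloro on an aromatic carbon. This puts hydrogen in place of chloro on an aromatic carbon, ortho to an ethoxy group.

Within the data shown here, the one measured step, a step that the two limits leave unreadable from compound 1 to compound 2, also concerns a substituent on an aromatic carbon, but it offers no size to carry over. The other reference point is the limit of > 10000 nM in this assay, at which 2 of the 3 values shown sit, reached by the two compounds that have no ethoxy group. Compound 4 keeps that ethoxy group, so a fall all the way to the limit is not the expected outcome. Among the measured compounds shown here, no measured step isolates the chloro of compound 3, which stands at 20 nM, and the estimate therefore stays wide.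

A moderate loss in this assay is expected, with an estimated 7.5-fold higher number from compound 3 to compound 4 (0.88 log units; beyond the scatter). For compound 4 the estimated value is 150 nM, with an expected range from 15 nM to 3000 nM.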

Compound 4, half-maximal inhibitory concentration: 20 nM
Estimate against measurement, compound 4: 7.5-fold (0.88 log units) above; measured number inside the range.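

In this assay, the chloro on the aromatic carbon ortho to an ethoxy group proves dispensable: replacing it with hydrogen gives no change at the digits printed from compound 3 to compound 4 (within the scatter), so this position tolerates either atom, a point that compound 3 alone could not show. The ethoxy group, by contrast, now has a clear link to the activity of this series, with ethoxy in place of chloro giving an at least 500-fold lower number from compound 2 to compound 4 (2.69 log units; beyond the scatter) and ethoxy in place of methyl giving an at least 500-fold lower number from compound 1 to compound 4 (2.69 log units; beyond the scatter). Both of these steps start from a limit and not from a number, and the step between compound 1 and compound 2 cannot be read at all: the limit of > 10000 nM in this assay, at which 2 of the 4 values shown sit.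

Whether the ethoxy group could give way to a methoxy, a longer chain such as propoxy, or an amine and still hold this level remains open in the compounds shown. Also open, on these data alone, is whether a fluoro or a methoxy on the carbon that held the chloro would leave the value unchanged, as hydrogen does.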